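Series notes: acetyl in place of the isopropyl ester

A few compounds are considered here, and "the series" means these few. Any claim that something is new, unique, unknown or untested is made for them only; others in the source may bear on it.

Measured compounds in a toxicity assay on NIH3T3 cells (Mus musculus) for cytotoxicity, read by resazurin assay; a higher number here means that more compound is needed for the effect, a lower number that less compound is needed:
Compound 1 `COC(=O)c1ccc(NCc2cncn2Cc2ccc(C#N)cc2)cc1-c1ccccc1` returns only a limit, > 10000 nM.
Compound 2 `COC(=O)c1ccc(NCc2cncn2Cc2ccc(C)cc2)cc1-c1ccccc1` gives 50000 nM.
Compound 3 `CC(C)OC(=O)c1ccc(NCc2cncn2Cc2ccc(-c3ccccc3)cc2)cc1-c1ccccc1` returns only a limit, > 10000 nM.

Compound 3 therefore stands at the assay limit, and so does compound 1, as the limit of > 10000 nM in this assay, at which 2 of the 3 values shown sit, records. Compound 2 is the only entry with a read number. Among the measured compounds shown here, the one step between two measured compounds that differ in a single place, a step that the limit leaves unreadable from compound 1 to compound 2, cannot be sized because the limit of > 10000 nM in this assay, at which 2 of the 3 values shown sit, covers compound 1; it also sits on an aromatic carbon, far from the carbonyl.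

Compound 4 `CC(=O)c1ccc(NCc2cncn2Cc2ccc(-c3ccccc3)cc2)cc1-c1ccccc1` is the next to be measured in this assay. It differs from compound 3 in one place:
methyl in place of isopropoxy on a carbonyl carbon

For the measured compounds named here, no measured step touches the carbonyl carbon, and the only step available in this assay is unreadable, so there is nothing to size the change against. With two of three values at the limit and the third far above it, the expectation for compound 4 is a step that the limit leaves unreadable from compound 3 to compound 4, that is, none that could be read beyond the scatter. Compound 4 is estimated at 30000 nM, with a range from 10000 nM to 100000 nM, and most likely reported only as a limit.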

Compound 4, half-maximal effective concentration: > 10000 nM
Compound 4: a limit, no number; the forecaster's own chance of this, stated with the estimate: 65%; the middle value is on the limit's open side.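

Compound 3 and compound 4 both return only a limit in this assay, so no step can be read between them: the limit of > 10000 nM in this assay, at which 3 of the 4 values shown sit.

Left open is whether the change from isopropoxycarbonyl to acetyl shifts the concentration needed for the effect in this assay at all, and in which direction.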